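Swapping a Biaryl Side Group for a Fused Bicycle

This account rests on a few compounds, and the source may have more. Where it says the series, first, only, none or still open, it means among the compounds named here.

Compound 1 `CN1CCN(c2ccc3nc(-c4cccc(-c5cccs5)c4)c(-c4ccncc4)n3n2)CC1` gives, in an assay on Sf9 cells for inhibition of receptor-interacting serine/threonine-protein kinase 3 (Homo sapiens), read by luminescence and 33P incorporation, with a stated time of 30 min, in the presence of a further agent that is not named here (on this read-out lower numbers stand for stronger inhibition and higher numbers for weaker inhibition), 270 nM. Of the two numbers recorded in this assay, compound 1 has the lowest; the nearest is compound 2 `CN1CCN(c2ccc3nc(-c4cccc(-c5ccccc5)c4)c(-c4ccncc4)n3n2)CC1`, which gives 450 nM. For the measured compounds named here, the step of a 1.7-fold higher number from compound 1 to compound 2 (0.22 log units; within the scatter) is the only change with a measurement so far.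

Compound 3 `CN1CCN(c2ccc3nc(-c4cccc5c4OCCO5)c(-c4ccncc4)n3n2)CC1` differs from compound 1 in one place: 2,3-dihydro-1,4-benzodioxin-5-yl in place of 3-(thiophen-2-yl)phenyl on an aromatic carbon. This exchanges the whole two-ring group rather than only one part of it, so the measured step from compound 1 to compound 2, which exchanged only thiophen-2-yl for phenyl and stayed within the scatter, bears on it only loosely and does not show what happens when the second ring is removed and a fused group enters. The data give no direct guide, so the expectation is uncertain; a weaker inhibition is taken as somewhat more likely than a stronger one, and the step of a 3.0-fold higher number from compound 1 to compound 3 (0.47 log units; beyond the scatter) is expected to lie beyond the scatter toward a higher number. Compound 3 is therefore estimated at 800 nM, with a likely range from 200 nM to 4000 nM.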

Compound 3, half-maximal inhibitory concentration: > 10000 nM
Compound 3: a limit, no number; the forecaster's own chance of this, stated with the estimate: 10%; middle value at least 12-fold (1.09 log units) away from the limit.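

Compound 3 gives > 10000 nM in this assay, and this is a limit of the assay, not a number. Even so, the exchange of the whole side group is a large one, an at least 37-fold higher number from compound 1 to compound 3 (1.56 log units; beyond the scatter), while the smaller exchange of one outer ring, a 1.7-fold higher number from compound 1 to compound 2 (0.22 log units; within the scatter), stayed within the scatter. So at this place on the five-membered aromatic ring with 2 nitrogen, the outer thiophen-2-yl can give way to phenyl with no readable change, but 3-(thiophen-2-yl)phenyl cannot give way to 2,3-dihydro-1,4-benzodioxin-5-yl without a large loss, whose full size stays unknown at the edge of the measured range: the limit of > 10000 nM in this assay, at which 1 of the 3 values shown sits.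

This one change removes the second aromatic ring and brings in a fused ring with two oxygens at the same time, so the compounds shown cannot say which of the two matters. Going by these compounds, a plain phenyl group with no second ring, or a 3-methoxyphenyl group, at this place would help to separate the two, and how either would compare with compound 1 remains open.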